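A few compounds are considered here, and "the series" means these few. Any claim that something is new, unique, unknown or untested is made for them only; others in the source may bear on it.

Measured compounds:
Compound 1 `COc1ccc(C2C(C#N)=C(/N=C/c3ccccc3Cl)Oc3nc(Nc4ccc(S(N)(=O)=O)cc4)sc32)cc1`: in a functional assay on MCF7 cells (Homo sapiens) for cytotoxicity, read by sulforhodamine B assay, with a stated time of 48 h (on this read-out lower numbers stand for stronger inhibition and higher numbers for weaker inhibition), compound 1 gives 10300 nM.
Compound 2 `COc1ccc(C2C(C#N)=C(/N=C/c3cccc(Br)c3)Oc3nc(Nc4ccc(S(N)(=O)=O)cc4)sc32)cc1`: in this assay compound 2 gives 9390 nM.

For the measured compounds named here, compound 2 stands beside compound 1, the two numbers within the scatter of each other; the only measured step is a 1.1-fold lower number from compound 1 to compound 2 (0.04 log units; within the scatter). Compound 3 `COc1ccc(C2C(C#N)=C(/N=C/c3ccc([N+](=O)[O-])cc3)Oc3nc(Nc4ccc(S(N)(=O)=O)cc4)sc32)cc1` differs from compound 2 by 4-nitrophenyl in place of 3-bromophenyl on a carbon with a double bond to nitrogen. Going by the values given here, that single step, also a swap of the aryl on the carbon with a double bond to nitrogen, is the only one that bears on this change, and the measured compounds give no example of a nitro group there. No step beyond the scatter in this assay is therefore expected: a 1.0-fold higher number from compound 2 to compound 3 (0.01 log units; within the scatter). Compound 3 is estimated at 9500 nM, between 4500 nM and 20000 nM.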

Compound 3, half-maximal inhibitory concentration: 9700 nM
Beside the measured number, compound 3's estimate is 1.0-fold (0.01 log units) below it; low and high end bracket the measured number.
By their numbers in this assay, from the lowest: compounds 2, 3 and 1 (each within the scatter of the next).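

In this assay, the first nitro-bearing aryl at this place matches both halogen-bearing ones: a 1.0-fold higher number from compound 2 to compound 3 (0.01 log units; within the scatter), and a 1.1-fold lower number from compound 1 to compound 3 (0.03 log units; within the scatter). The 2-chlorophenyl, 3-bromophenyl and 4-nitrophenyl groups on the carbon with a double bond to nitrogen thus all stand within the scatter of one another, despite the change of substituent and of its place on the ring. Nothing on hand accounts for this sameness.

On these data alone, whether an aryl carrying an amine or a carboxylic acid would shift the number beyond the scatter remains open. So does the effect of replacing the aryl with a longer alkyl chain.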